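The source may hold more compounds than are shown below. What is called first, only, known or untested is meant among the compounds shown, and "the series" means these compounds.

The measured compounds are these: compound 1 `ClCc1ccc(Cn2cnc3c(Cl)ncnc32)cc1`, compound 2 `Nc1nc(Cl)c2ncn(Cc3ccc(CCl)cc3)c2n1` and compound 3 `ClCc1ccccc1Cn1cnc2c(Cl)ncnc21`. In a functional assay on A498 cells (Homo sapiens) for cytotoxicity, read by sulforhodamine B assay, with a stated time of 48 h (a higher number here means that more compound is tolerated, a lower number that less compound is tolerated), compound 1 gives 57500 nM. In this assay compound 3 gives 58900 nM. For compound 2 the result in this assay is a limit of the assay and not a number, reported as > 100000 nM.

Compound 1 and compound 2 differ in one place, (amino in place of hydrogen on an aromatic carbon). The step in this assay is an at least 1.7-fold higher number from compound 1 to compound 2 (0.24 log units; that floor lies within the scatter), and its size is known only as a floor because of the limit of > 100000 nM in this assay, at which 1 of the 3 values shown sits. Compound 1 and compound 3 share the same atoms joined differently; how the two cores differ is not broken down here. Their values in this assay lie within the scatter of each other, so no order between them is claimed.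

Compound 4 `Nc1nc(Cl)c2ncn(Cc3ccccc3CCl)c2n1` is not yet measured. It stands to compound 3 as compound 2 stands to compound 1: the change is amino in place of hydrogen on an aromatic carbon, the same change at the same kind of place. Since compound 3 and compound 1 give values within the scatter of each other, the step seen from compound 1 to compound 2 is taken as the guide. Compound 4 is expected to show a step of a 2.0-fold higher number from compound 3 to compound 4 (0.31 log units; beyond the scatter) in this assay. For compound 4 the estimate in this assay is 120000 nM, expected to fall between 55000 nM and 300000 nM, with a real chance that only a limit is reported.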

Compound 4, concentration lethal to 50% of the cells: 95500 nM
Compound 4: middle estimate off by 1.3-fold (0.10 log units), on the high side; the measured number falls inside the stated range.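

In this assay, among the compounds shown here, the change from hydrogen to amino gives a 1.6-fold higher number from compound 3 to compound 4 (0.21 log units; within the scatter), so on the core of compound 3 the change produces no step that can be told apart from the scatter. Set beside the step on the core of compound 1, this reading can be compared only in part, and neither step is shown to lie beyond the scatter: the same change on two cores in this assay, an at least 1.7-fold higher number (0.24 log units; that floor lies within the scatter) from compound 1 to compound 2 and a 1.6-fold higher number (0.21 log units; within the scatter) from compound 3 to compound 4; the limit leaves it open whether they differ What the pair of steps does not show is the full size of the step on the core of compound 1, or whether the change carries over from one core to the other with the same size, because compound 2 is reported only at a limit of the assay: the limit of > 100000 nM in this assay, at which 1 of the 4 values shown sits.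

The compounds shown leave open whether another group at the same place on the ring, such as a methyl group, a hydroxyl group or a dimethylamino group, would give a step beyond the scatter in this assay. They also leave open how the numbers would stand on either core with a hydroxymethyl group or a plain methyl group in place of the chloromethyl group.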